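From a Methylpyridine to an Aminopyridine on a Shared Core

The compounds below may be only part of what the source reports. "The series", "measured", "known", "first", "only" and "open" are said of these compounds alone.

Compound 2 `Cc1ccc(-c2cc(F)cc(-n3nnc(-c4ccccn4)n3)c2)cn1` gives 57 nM in a functional assay for antagonist activity at metabotropic glutamate receptor 5 (Rattus norvegicus); on this read-out higher numbers stand for weaker inhibition and lower numbers for stronger inhibition. Among the measured compounds shown here, only one other compound has been measured: compound 1 `Cc1ncccc1-c1cc(F)cc(-n2nnc(-c3ccccn3)n2)c1` gives 41 nM, and the step of a 1.4-fold higher number from compound 1 to compound 2 (0.14 log units; within the scatter) lies within the scatter, so the two compounds cannot be told apart on this read-out. Compound 3 `Nc1ccncc1-c1cc(F)cc(-n2nnc(-c3ccccn3)n2)c1` has not yet been measured. It differs from compound 2 in one place: 4-aminopyridin-3-yl in place of 6-methylpyridin-3-yl on an aromatic carbon. For the measured compounds named here, the single measured step, from compound 1 to compound 2, only shifts a methyl group on the same pyridine and changes the number little; no measured step shows what exchanging that methyl for an amino group does. The expectation is therefore wide. Compound 3 is estimated at 80 nM, with a range of 25 nM to 250 nM. This estimate means a step of a 1.4-fold higher number from compound 2 to compound 3 (0.15 log units; within the scatter), which is expected to stay within the scatter or only a little beyond it.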

Compound 3, half-maximal inhibitory concentration: 108 nM
For compound 3 the middle estimate is 1.4-fold (0.13 log units) below the measured one; measured number inside the range.
By their numbers in this assay, from the lowest: compounds 1, 2 and 3 (each within the scatter of the next, the first and the last beyond it).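

In this assay, 4-aminopyridin-3-yl at this position gives a 1.9-fold higher number from compound 2 to compound 3 (0.28 log units; within the scatter), so on this read-out the amino-substituted ring cannot be told apart from 6-methylpyridin-3-yl, even though it brings a hydrogen-bond donor that the methyl-substituted ring lacks. Measured against 2-methylpyridin-3-yl, the same change gives a 2.6-fold higher number from compound 1 to compound 3 (0.42 log units; beyond the scatter), a modest weakening of inhibition and the only step among these compounds that lies beyond the scatter. The data shown offer no explanation for this difference.

The compounds shown leave open how a dimethylamino or methoxy group in place of the amino group on this pyridine would fare. They also leave open whether a phenyl ring carrying an amino group would give inhibition close to that of the pyridine compounds.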